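A Longer Chain End on Compound 2

The source may hold more compounds than are shown below. What is called first, only, known or untested is meant among the compounds shown, and "the series" means these compounds.

- compound 1 `CNCCCNCCCNC` gives > 100000 nM as its value
- compound 2 `CCNCCCNCCCN` gives > 100000 nM as its value
- compound 3 `CCCNCCCNCCCNCCC` gives > 100000 nM as its value

The only read-out here is a functional assay on L1210 cells (Mus musculus) for inhibition, with a stated time of 48 h (a lower number here means a stronger inhibitor, a higher number a weaker inhibitor), and all of the values above are limits of the assay, not numbers. In this assay compound 2 stands at > 100000 nM, which is only a limit. The same holds across the series, with the limit of > 100000 nM in this assay, at which 3 of the 3 values shown sit, so compound 2 cannot be ranked against compound 1 or compound 3.

The next compound is compound 4 `CCNCCCCNCCCNCC`, which has yet to be measured. It differs from compound 2 by (ethylamino)methyl in place of amino on a saturated chain carbon, three bonds along the chain from an amine nitrogen, so (ethylamino)methyl takes the place of amino on a saturated chain carbon, three bonds along the chain from an amine nitrogen.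

Going by the values given here, no measured step gives a size to work from. Compound 3 also carries ethyl-bearing chain ends and gives > 100000 nM as a limit, so no large gain is expected from this change. The expected move is a number no higher from compound 2 to compound 4 (the limit leaves the size open) and would, if it appears at all, be small and towards stronger inhibition. Another reading at the limit is the likeliest single outcome. For compound 4 the estimate is 100000 nM, with an expected range from 30000 nM to 300000 nM as the result.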

Compound 4, half-maximal inhibitory concentration: 100000 nM
For compound 4 middle estimate and measured number coincide at the digits printed; the measured number falls inside the stated range.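

In this assay, going by these compounds alone, compound 4 gives 100000 nM, the first value that is a number and not a limit. Putting (ethylamino)methyl in place of amino on a saturated chain carbon, three bonds along the chain from an amine nitrogen, gives a number no higher from compound 2 to compound 4 (the limit leaves the size open), so the change does show a direction, but it gives no size. The result therefore still lies at the edge of what the assay reads, as most of the series does: the limit of > 100000 nM in this assay, at which 3 of the 4 values shown sit.

Within the data shown here, how much of a gain, if any, this change brings stays open, since the value for compound 2 is only a limit and no number can be set against the one for compound 4. Also open, from the compounds shown here alone, is whether a carboxylic acid or a phenyl ring at this chain end would bring the number clearly down from the value of compound 4.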